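The source may report more compounds than this note shows. Statements on the series, on what has been measured and on what is new or still open speak of the compounds shown alone.

Series notes. Three amide acids share one core. Compound 1 `CCCCOc1ccc(C(=O)Nc2cccc(C(=O)O)c2)cc1` carries a propyl group on the saturated chain carbon bound to an oxygen on an aromatic ring; in an assay on isolated protein for agonist activity at Bile acid receptor (Homo sapiens), read by TR-FRET, with a stated time of 3 h, in the absence of a further agent (on this read-out higher numbers stand for an effect only at larger amounts of compound and lower numbers for an effect already at smaller amounts), compound 1 gives 105 nM. Compound 2 `O=C(O)c1cccc(NC(=O)c2ccc(OCc3ccccc3)cc2)c1` carries phenyl at that carbon, and in this assay compound 2 gives 135 nM. Compound 3 `Cc1cccc(COc2ccc(C(=O)Nc3cccc(C(=O)O)c3)cc2)c1` carries 3-methylphenyl there; in this assay compound 3 gives 259 nM. Among the compounds with values here, of the three numbers compound 3 shows the highest, though only the step of a 2.5-fold higher number from compound 1 to compound 3 (0.39 log units; beyond the scatter) lies beyond the scatter, while a 1.9-fold higher number from compound 2 to compound 3 (0.28 log units; within the scatter) and a 1.3-fold higher number from compound 1 to compound 2 (0.11 log units; within the scatter) stay within it.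

Compound 4 `O=C(O)c1cccc(NC(=O)c2ccc(OCc3cccc(-c4ccccc4)c3)cc2)c1` is not yet measured. It differs from compound 3 in one place: phenyl in place of methyl on an aromatic carbon. The step bearing most directly on this change is a 1.9-fold higher number from compound 2 to compound 3 (0.28 log units; within the scatter), where a group first entered that aromatic carbon; a 2.5-fold higher number from compound 1 to compound 3 (0.39 log units; beyond the scatter) shows the whole enlarged substituent giving a higher number than the propyl group. Both point, weakly, towards a higher number as the group at that carbon grows further, though only one passed the scatter. For compound 4 a modest rise is therefore expected, a 1.5-fold higher number from compound 3 to compound 4 (0.19 log units; within the scatter), with a real chance of no change beyond the scatter. The estimate for compound 4 in this assay is 400 nM, ranging from 150 nM to 1100 nM.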

Compound 4, half-maximal effective concentration: 319 nM
For compound 4 the middle estimate is 1.3-fold (0.10 log units) above the measured one, and the stated range covers the measured number.
By their numbers in this assay, from the lowest: compounds 1, 2, 3 and 4 (each within the scatter of the next, the first and the last beyond it).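

At the aromatic carbon meta to a large group, a methyl giving way to a whole phenyl ring leaves the number in this assay without a change that can be told apart from the scatter, with a 1.2-fold higher number from compound 3 to compound 4 (0.09 log units; within the scatter). Counted from hydrogen at that carbon, phenyl gives a step that does pass the scatter, though only modestly, with a 2.4-fold higher number from compound 2 to compound 4 (0.37 log units; beyond the scatter), while methyl stays inside it, with a 1.9-fold higher number from compound 2 to compound 3 (0.28 log units; within the scatter); the position therefore accepts a much larger aromatic group at a modest cost overall, and the number does not keep climbing in proportion to the size of the group. No measurement is at hand that would explain this behaviour.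

Still open, on these data alone, is whether the flat stretch from methyl to phenyl holds for groups of another kind at this carbon, such as a methoxy group, an amine or a pyridyl ring, which would help separate the size of a group from its nature. Also open, as far as these compounds go, is whether a substituent on the added phenyl ring, such as a fluorine or a carboxylic acid, moves the number in either direction.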